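The source may hold more compounds than are shown below. What is called first, only, known or untested is meant among the compounds shown, and "the series" means these compounds.

Compound 1 `CC(C)c1ccc(Cc2sc3c(c2C(=O)N[C@@H](C)c2ccc(C(=O)O)cc2)CCOC3)cc1`: in a functional assay on CHO/Galpha16 cells for antagonist activity at prostaglandin E2 receptor EP4 subtype (Homo sapiens), read by calcium flux, with a stated time of 15 min (a lower number here means a stronger inhibitor, a higher number a weaker inhibitor), compound 1 gives 2.7 nM.
Compound 2 `COc1cccc(C#Cc2sc3c(c2C(=O)N[C@@H](C)c2ccc(C(=O)O)cc2)CCOC3)c1`: in this assay compound 2 gives 12.4 nM.

Within the data shown here, of the two measured compounds, compound 2 gives the higher number; the single measured step, a 4.6-fold higher number from compound 1 to compound 2 (0.66 log units; beyond the scatter), separates it from compound 1. Compound 3 `C[C@H](NC(=O)c1c(NC(=O)c2ccc(F)cc2)sc2c1CCOC2)c1ccc(C(=O)O)cc1` has not yet been measured. Relative to compound 2 the change is ((4-fluorophenyl)carbonyl)amino in place of 2-(3-methoxyphenyl)ethynyl on an aromatic carbon. Among the measured compounds shown here, the only measured step that bears on this position is a 4.6-fold higher number from compound 1 to compound 2 (0.66 log units; beyond the scatter), which exchanged one carbon-linked aromatic group for another; the group that enters in compound 3 is joined through an amide instead, so that step gives no direct guide, only a sign that this position tolerates varied groups with modest movement in the number. The author therefore expects a change in this assay of about a 1.2-fold lower number from compound 2 to compound 3 (0.09 log units; within the scatter), with low confidence in its direction. For compound 3 the estimate is 10 nM, within a range from 2 nM to 50 nM.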

Compound 3, half-maximal inhibitory concentration: > 1000 nM
Compound 3 was reported as a limit (the forecaster's own chance of this, stated with the estimate: 3%); middle value at least 100-fold (2.00 log units) from the limit.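

Compound 3 is reported in this assay only as a limit: the limit of > 1000 nM in this assay, at which 1 of the 3 values shown sits.

With ((4-fluorophenyl)carbonyl)amino on the aromatic carbon next to the ring sulfur, the result is an at least 80-fold higher number from compound 2 to compound 3 (1.90 log units; beyond the scatter) and an at least 370-fold higher number from compound 1 to compound 3 (2.56 log units; beyond the scatter). The earlier step, a 4.6-fold higher number from compound 1 to compound 2 (0.66 log units; beyond the scatter), had shown only a modest change between two carbon-linked groups, whereas these steps show that this position does not accept every group with a six-membered aromatic ring, even one equal in heavy-atom count to 2-(3-methoxyphenyl)ethynyl.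

The compounds shown do not separate the effect of the amide link from that of the 4-fluorophenyl group. Nor do they show how a benzoylamino group without the fluorine, an acetylamino group or a free amine on this carbon would behave.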